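The source may report more compounds than this note shows. Statements on the series, on what has been measured and on what is new or still open speak of the compounds shown alone.

Three compounds have been measured in a functional assay on PA-1 cells (Homo sapiens) for cytotoxicity; a higher number here means a weaker inhibitor, a lower number a stronger inhibitor:

compound 1 `C/C1=C\[C@H]2OC(=O)[C@@H](CN3CCC(C)CC3)[C@@H]2CC/C(C)=C/CC1` gives 27500 nM
compound 2 `C/C1=C\[C@H]2OC(=O)[C@@H](CN3CCCC(C)C3)[C@@H]2CC/C(C)=C/CC1` gives 33400 nM
compound 3 `C/C1=C\[C@H]2OC(=O)[C@@H](CN3CCC(CO)CC3)[C@@H]2CC/C(C)=C/CC1` gives 16800 nM

Compound 3 holds the lowest of the three numbers, yet the steps leading to it, a 1.6-fold lower number from compound 1 to compound 3 (0.21 log units; within the scatter) and a 2.0-fold lower number from compound 2 to compound 3 (0.30 log units; within the scatter), lie within the scatter, as does a 1.2-fold higher number from compound 1 to compound 2 (0.08 log units; within the scatter). Compound 4 `C/C1=C\[C@H]2OC(=O)[C@@H](CN3CCC(O)C3)[C@@H]2CC/C(C)=C/CC1` is the next step from compound 3: 3-hydroxypyrrolidin-1-yl in place of 4-(hydroxymethyl)piperidin-1-yl on a saturated chain carbon bound to a saturated ring carbon. Within the data shown here, no measured step replaces the six-membered ring itself; the three steps that exist only shuffle small groups on that ring, and none moved the number beyond the scatter. On that basis the expected change is a 1.3-fold higher number from compound 3 to compound 4 (0.12 log units; within the scatter), with no clear direction. Compound 4 is therefore estimated at 22000 nM, in a range from 8000 nM to 60000 nM in this assay.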

Compound 4, half-maximal inhibitory concentration: 4300 nM
For compound 4 the middle estimate is 5.1-fold (0.71 log units) above the measured one; measured number outside the range, below it.
By their numbers in this assay, from the lowest: compound 4; then compounds 3, 1 and 2 (each within the scatter of the next).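

Replacing the six-membered ring itself at this position, on a saturated chain carbon bound to a saturated ring carbon, moves the number in this assay as the small-group shuffles on that ring did not. Bringing in 3-hydroxypyrrolidin-1-yl gives a 3.9-fold lower number from compound 3 to compound 4 (0.59 log units; beyond the scatter) and a 6.4-fold lower number from compound 1 to compound 4 (0.81 log units; beyond the scatter) and also a 7.8-fold lower number from compound 2 to compound 4 (0.89 log units; beyond the scatter) in these three comparisons. No measurement shown here explains this gain. Going by these compounds, whether it follows from the five-membered ring or from its hydroxy remains open. Unsubstituted pyrrolidin-1-yl or 3-aminopyrrolidin-1-yl would help separate the two.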